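The compounds below may be only part of what the source reports. "The series", "measured", "known", "first", "only" and "open" are said of these compounds alone.

Series notes. The shared core is set by compound 1 `O=C(Nc1nn(-c2ccccc2)c(=O)c2ccccc12)c1ccco1`, which in an assay on CHO cells for displacement of a labelled ligand from adenosine receptor A1 (Homo sapiens), tested at 10 uM (a higher number here means more inhibition at the concentration tested (going by the name of the read-out), a lower number less inhibition), gives 23%. Compound 2 `CC(=O)Nc1nn(-c2ccccc2)c(=O)c2ccccc12` carries a methyl on the carbonyl carbon and in this assay gives 52%. Compound 3 `O=C(Nc1nn(-c2ccccc2)c(=O)c2ccccc12)c1ccc(Cl)cc1` carries a 4-chlorophenyl there and in this assay gives 26%. Among the three numbers compound 3 stands second highest; its nearest neighbour is compound 1, within the scatter, its furthest is compound 2 a number 26 percentage points lower from compound 2 to compound 3 (beyond the scatter).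

Compound 4 `Cc1ccc(NC(=O)Nc2nn(-c3ccccc3)c(=O)c3ccccc23)cc1` is the next step from compound 3: (4-methylphenyl)amino in place of 4-chlorophenyl on a carbonyl carbon. The measured steps that touch the same carbonyl carbon are a number 3 percentage points higher from compound 1 to compound 3 (within the scatter) and a number 26 percentage points lower from compound 2 to compound 3 (beyond the scatter). The aryl-bearing compounds 1 and 3 sit close together, and only the methyl of compound 2 stands apart. Within the data shown here, no measured step replaces an aryl with an arylamino on that carbon, so the size of the present change has no direct precedent. Since compound 4 keeps a six-membered carbon ring on the carbonyl carbon, as compound 1 and compound 3 do, the expectation for compound 4 in this assay is no step beyond the scatter, a number 4 percentage points higher from compound 3 to compound 4 (within the scatter). Compound 4 is therefore estimated at 30%, with a range from 10% to 55%.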

Compound 4, a percentage reported as inhibition, at one concentration (the size of the read-out at that concentration, not a potency): 29%
Estimate against measurement, compound 4: 1 percentage points above; measured number inside the range.
By their numbers in this assay, from the lowest: compounds 1, 3 and 4 (each within the scatter of the next); then compound 2.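

In this assay, among these compounds, (4-methylphenyl)amino in place of 4-chlorophenyl on the carbonyl carbon gives a step with no measured precedent (a number 3 percentage points higher from compound 3 to compound 4 (within the scatter)), so bringing in a nitrogen and one hydrogen-bond donor while keeping a six-membered aromatic ring of carbon only leaves the read-out unchanged within the scatter. Against furan-2-yl the picture is the same (a number 6 percentage points higher from compound 1 to compound 4 (within the scatter)), while against methyl the step is beyond the scatter (a number 23 percentage points lower from compound 2 to compound 4 (beyond the scatter)), so that among these four compounds the three ring-bearing groups stay together and compound 2 alone stands apart. Nothing at hand gives a reason for the close grouping of the ring-bearing groups or for the gap to the methyl.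

On these data alone, it remains open whether other small groups without a ring on the carbonyl carbon, such as ethyl or methylamino, would stay close to compound 2 (52%) or fall back towards the ring-bearing compounds. As far as these compounds go, it is also open whether the level of compound 4 would hold with a carboxylic acid or a dimethylamino group in place of the methyl on its phenyl ring, or with a longer chain between the ring and the carbonyl carbon.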